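The source may hold more compounds than are shown below. What is called first, only, known or untested is meant among the compounds shown, and "the series" means these compounds.

Compound 1 `CS/C(=N\C(=O)c1sccc1Cl)NC(=O)c1sccc1Cl`, compound 2 `CS/C(=N\C(=O)c1ccno1)NC(=O)c1ccno1` and compound 3 `O=C(/N=C(/NC(=O)c1ccco1)[Se]Cc1ccccc1)c1ccco1` have been run in a functional assay on HT-29 cells (Homo sapiens) for cytotoxicity, read by MTT assay, with a stated time of 72 h; on this read-out lower numbers stand for stronger inhibition of growth and higher numbers for weaker inhibition of growth. Compound 1 gives 35600 nM in this assay, the higher of the two numbers recorded; compound 3 gives 7190 nM, lower by a margin beyond the scatter. For compound 2 the result is only a limit of this assay, > 100000 nM. Compound 4 `C[Se]/C(=N\C(=O)c1sccc1Cl)NC(=O)c1sccc1Cl` is not yet measured; it differs from compound 1 by a group of 2 heavy atoms (1 carbon, 1 selenium; no ring) in place of a group of 2 heavy atoms (1 carbon, 1 sulfur; no ring), on a carbon with a double bond to nitrogen. Among the compounds with values here, no step of this kind has been measured within the set, and compound 3, the only other member carrying selenium, differs from compound 1 in other places as well. The change is expected to move the number little, if anything downward, with an expected step of a 1.4-fold lower number from compound 1 to compound 4 (0.15 log units; within the scatter) that stays within the scatter. Compound 4 is estimated at 25000 nM, between 8000 nM and 80000 nM.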

Compound 4, concentration for 50% growth inhibition: 4.9 nM
Compound 4: the middle estimate sits 5100-fold (3.71 log units) above what was measured; measured number below the stated range.
By their numbers in this assay, from the lowest: compound 4; then compound 3; then compound 1. At a limit, above all of these: compound 2.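

In this assay, exchanging methylsulfanyl for the group carrying selenium in its place, on a carbon with a double bond to nitrogen, gives a 7300-fold lower number from compound 1 to compound 4 (3.86 log units; beyond the scatter). This single exchange therefore marks the position as highly sensitive, which compound 3 could not show, as it differs from compound 1 in other places as well. No measurement shown accounts for the size of this step.

From the compounds shown here alone, whether the same exchange gives a comparable step on other cores remains open. So does the effect of a longer chain on selenium, or of an amine at this carbon.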